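The source may hold more compounds than are shown below. What is called first, only, known or untested is meant among the compounds shown, and "the series" means these compounds.

Working notes on the series. The shared core is held constant; the compounds differ only in the group on the ring amine nitrogen. Compound 1 `NC(=O)c1c(NC(=O)c2ccccc2Cl)sc2c1CCN(Cc1cc(Cl)cc(Cl)c1)C2` gives 19600 nM in a functional assay on HeLa cells (Homo sapiens) for antiproliferative activity, with a stated time of 24 h; a higher number here means a weaker inhibitor, a lower number a stronger inhibitor. Compound 2 `NC(=O)c1c(NC(=O)c2ccccc2Cl)sc2c1CCN(C(=O)Nc1ccccc1Cl)C2` gives 45400 nM in this assay, and compound 3 `NC(=O)c1c(NC(=O)c2ccccc2Cl)sc2c1CCN(C(=S)Nc1ccccc1I)C2` gives 29000 nM in this assay. The step of a 2.3-fold higher number from compound 1 to compound 2 (0.36 log units; beyond the scatter) is the only one beyond the scatter; a 1.5-fold higher number from compound 1 to compound 3 (0.17 log units; within the scatter) and a 1.6-fold lower number from compound 2 to compound 3 (0.19 log units; within the scatter) both fall within it. Compound 3 therefore stands second highest of the three numbers, with no separation from compound 1 or compound 2 that exceeds the scatter.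

Compound 4 `NC(=O)c1c(NC(=O)c2ccccc2Cl)sc2c1CCN(C(=S)Nc1ccc(C(F)(F)F)cc1)C2` differs from compound 3 by 4-(trifluoromethyl)phenyl in place of 2-iodophenyl on an amide-type nitrogen. Going by the values given here, no measured step alters the substituent on the aryl of the thiocarbonyl-bearing nitrogen; the nearest comparison, a swap of the whole group on the ring amine nitrogen, read a 1.6-fold lower number from compound 2 to compound 3 (0.19 log units; within the scatter). The change in compound 4 is expected to move the number little, a 1.0-fold higher number from compound 3 to compound 4 (0.01 log units; within the scatter). Compound 4 is estimated at 30000 nM in this assay, with a range from 12000 nM to 75000 nM.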

Compound 4, half-maximal inhibitory concentration: > 50000 nM
Compound 4 gave a limit, no number (the forecaster's own chance of this, stated with the estimate: 10%); middle value at least 1.6-fold (0.22 log units) from the limit.
By their numbers in this assay, from the lowest: compounds 1, 3 and 2 (each within the scatter of the next, the first and the last beyond it). At a limit, above all of these: compound 4.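

Compound 4 gives a limit and not a number in this assay: the limit of > 50000 nM in this assay, at which 1 of the 4 values shown sits. The earlier compounds shown here differ in the whole group on the ring amine nitrogen, whereas here only the aryl group on the amide-type nitrogen changes, with 4-(trifluoromethyl)phenyl in place of 2-iodophenyl, and the step reads an at least 1.7-fold higher number from compound 3 to compound 4 (0.23 log units; that floor lies within the scatter). On these data alone, that floor separates compound 4 from compound 3 by no more than the scatter, so the true size of this change stays unknown.

The step alters both the substituent and the name-given place on the aryl ring, so the compounds shown cannot tell these two apart. As far as these compounds go, how this position responds to an amine or a carboxylic acid on that aryl ring also remains open.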